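Changing the saturated ring on the core of compound 3

The source may report more compounds than this note shows. Statements on the series, on what has been measured and on what is new or still open speak of the compounds shown alone.

Compound 1 `CC(C)CNC(=O)n1c(=O)oc2c(C3CCN(C)CC3)cccc21`, compound 2 `CC(C)CNC(=O)n1c(=O)oc2ccc(C3CCN(C)CC3)cc21` and compound 3 `CN1CCC(c2ccc3c(c2)oc(=O)n3C(=O)NCCCCc2ccccc2)CC1=O` share one core and have all been tested in an ADME assay on a cell-free system (plasma, Mus musculus) for metabolic stability, read by LC-MS, tested at 2 uM; a higher number here means that the compound lasts longer, a lower number that the compound disappears faster. Compound 1 gives 0.667 h, compound 2 gives 0.5 h, and compound 3 gives 0.6 h. The number for compound 3 lies within the usual scatter of both other numbers, so the three compounds cannot be told apart. Compound 4 `CN1CCN(c2ccc3c(c2)oc(=O)n3C(=O)NCCCCc2ccccc2)C(=O)C1` has not yet been measured; it differs from compound 3 in one place: 4-methyl-2-oxopiperazin-1-yl in place of 1-methyl-2-oxopiperidin-4-yl on an aromatic carbon. Within the data shown here, no step between measured compounds resembles this change, and the three known numbers are all alike. In this assay the change is therefore expected to be small, with no clear direction: no change at the digits printed from compound 3 to compound 4 (within the scatter). Compound 4 is estimated at 0.6 h, between 0.3 h and 1.2 h.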

Compound 4, half-life: 0.333 h
Compound 4: the middle estimate sits 1.8-fold (0.26 log units) above what was measured, and the stated range covers the measured number.
By their numbers in this assay, from the lowest: compounds 4, 2, 3 and 1 (each within the scatter of the next).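

In this assay, 4-methyl-2-oxopiperazin-1-yl in place of 1-methyl-2-oxopiperidin-4-yl on this aromatic carbon gives a 1.8-fold lower number from compound 3 to compound 4 (0.26 log units; within the scatter). Among these compounds, this is the only step that can be read at this position, and it shows that this exchange of one six-membered ring for another, with the same count of heavy atoms, stays within the scatter. No measured evidence bears on what lies behind this number. The compounds shown leave open whether an open-chain amine or a carboxylic acid on this aromatic carbon would give a number beyond the scatter.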